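Urea series: isopropyl to methoxy at the aryl ring

The source may hold more compounds than are shown below. What is called first, only, known or untested is meant among the compounds shown, and "the series" means these compounds.

Measured so far:
compound 1 `CC(C)c1ccccc1NC(=O)N[C@H](C)c1ccccc1` — 17%
compound 2 `CC(C)c1ccccc1NC(=O)N[C@@H](C)c1ccccc1` — 93%

In an ADME assay on the whole organism with Oryza sativa as the target, tested at 10 uM (on this read-out lower numbers stand for a stronger effect and higher numbers for a weaker effect at the one concentration tested), compound 1 gives 17% and compound 2 gives 93%. Among the measured compounds shown here, compound 2 therefore stands highest of the two numbers, with compound 1 as its nearest neighbour; the one step recorded is a number 76 percentage points higher from compound 1 to compound 2 (beyond the scatter), and the only thing that separates the pair is the fact that compounds 1 and 2 differ only in the configuration as drawn.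

The next compound, compound 3 `COc1ccccc1NC(=O)N[C@@H](C)c1ccccc1`, keeps the configuration of compound 2 and changes the substituent on the ring instead: methoxy in place of isopropyl on an aromatic carbon. For the measured compounds named here, no measured step covers such a change; the single step in hand concerns configuration alone, so it gives no guide to the size or direction of the change in this assay from compound 2 to compound 3. With nothing to go on, the working expectation is a number close to that of compound 2, with a wide margin on the lower side because the assay has room to move only downward from there. Compound 3 is estimated at 80% in this assay, within 45% to 100%. The step this implies is expected to be a number 13 percentage points lower from compound 2 to compound 3 (beyond the scatter).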

Compound 3, a percentage reported as activity, at one concentration (the size of the read-out at that concentration, not a potency): 95%
For compound 3 the middle estimate is 15 percentage points below the measured one; measured number inside the range.
By their numbers in this assay, from the lowest: compound 1; then compounds 2 and 3 (each within the scatter of the next).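

In this assay, methoxy in place of isopropyl on an aromatic carbon, ortho to a large group, comes out as a number 2 percentage points higher from compound 2 to compound 3 (within the scatter). In the configuration of compound 2, this position therefore shows no response to the exchange of an all-carbon group for one that carries an oxygen and a hydrogen-bond acceptor. The only step beyond the scatter in the series remains a number 76 percentage points higher from compound 1 to compound 2 (beyond the scatter), and what separates that pair is configuration alone: the fact that compounds 1 and 2 differ only in the configuration as drawn

Both compound 2 and compound 3 carry the same configuration and sit high on the read-out, so the flat step does not tell whether methoxy would also leave the number unchanged in the configuration of compound 1, which gives 17%. Also open, as far as these compounds go, is how this assay would respond to other groups on the same aromatic carbon, such as an amine, a carboxylic acid or a longer chain, in either configuration.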